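The compounds below may be only part of what the source reports. "The series", "measured", "known", "first", "only" and "open" are said of these compounds alone.

Measured compounds: compound 1 `NC(=O)CN(CCC(c1ccccc1)c1ccccc1)C(=O)CN(CCC(c1ccccc1)c1ccccc1)C(=O)CNCC1CCCO1`, 21300 nM; compound 2 `O=C1CN(CC2CCCO2)C(=O)CN1CCC(c1ccccc1)c1ccccc1`, "not determined" (no result reported).

Within the data shown here, compound 1 holds the only number in an ADME assay on Jurkat cells (Homo sapiens) for cytotoxicity, with a stated time of 72 h; on this read-out lower numbers stand for stronger inhibition of growth and higher numbers for weaker inhibition of growth; for compound 2 nothing was recorded in this assay. Compound 3 `NC(=O)CN(CCC(c1ccccc1)c1ccccc1)C(=O)CNCCC(c1ccccc1)c1ccccc1` is compound 1 with one group removed: hydrogen in place of ((((oxolan-2-yl)methyl)amino)methyl)carbonyl on an amine nitrogen. Among the measured compounds shown here, no step between two measured compounds is available, so the size of this change cannot be read from the data. In this assay compound 1 gives 21300 nM, a weak inhibition of growth. Compound 3 is expected to stay close, with the step of a 1.2-fold higher number from compound 1 to compound 3 (0.07 log units; within the scatter) expected to lie within the usual scatter. The estimate for compound 3 is 25000 nM, from 8000 nM to 80000 nM.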

Compound 3, concentration for 50% growth inhibition: 10500 nM
Compound 3: the middle estimate sits 2.4-fold (0.38 log units) above what was measured; measured number inside the range.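

In this assay, replacing the ((((oxolan-2-yl)methyl)amino)methyl)carbonyl on the amine nitrogen with hydrogen gives a 2.0-fold lower number from compound 1 to compound 3 (0.31 log units; beyond the scatter) and so a modest gain in growth inhibition. This group is therefore not required for the activity of compound 1 on this read-out, and compound 3 keeps that activity without it. Nothing available explains the shift.

The compounds shown leave open whether the oxolane ring or the rest of the removed group accounts for the difference. They also leave open how a small acetyl or methyl group on this nitrogen would compare with hydrogen.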